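The source may hold more compounds than are shown below. What is called first, only, known or untested is meant among the compounds shown, and "the series" means these compounds.

Working notes on the series built around the core of compound 1 `CC(C)Cc1nn(-c2cccc(F)c2)cc1C(=O)NCc1ccc(F)cc1`. In a toxicity assay on HepG2 2.2.15 cells (Homo sapiens) for cytotoxicity, read by CCK-8 assay, with a stated time of 8 days (a higher number here means that more compound is tolerated, a lower number that less compound is tolerated), compound 1 gives only a limit, > 100000 nM. For the measured compounds named here, compound 2 `CC(C)Cc1nn(-c2nccs2)cc1C(=O)Nc1ccc(F)cc1` is the one member with a number in this assay, where compound 2 gives 83700 nM. The value of compound 1 sits at the limit of > 100000 nM in this assay, at which 1 of the 2 values shown sits. Compound 2 thus stands as the single numerical point, under that limit. Compound 3 `CC(C)Cc1nn(-c2cccc(F)c2)cc1C(=O)Nc1ccc(F)cc1` differs from compound 2 by 3-fluorophenyl in place of 1,3-thiazol-2-yl on an aromatic nitrogen. Going by the values given here, no measured pair shows this change alone, so the step from compound 2 to compound 3 has no precedent here; compound 1 carries the same 3-fluorophenyl and reaches only the limit. The expected step in this assay, a 1.3-fold higher number from compound 2 to compound 3 (0.12 log units; within the scatter), is toward more compound tolerated, but modest. Compound 3 is estimated at 110000 nM, within 50000 nM to 250000 nM, with a fair chance that this assay again reports only a limit.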

Compound 3, half-maximal cytotoxic concentration: 36200 nM
Estimate against measurement, compound 3: 3.0-fold (0.48 log units) above, and the stated range ends above it.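

In this assay, the group on the aromatic nitrogen now has a measured step of its own: 3-fluorophenyl in place of 1,3-thiazol-2-yl gives a 2.3-fold lower number from compound 2 to compound 3 (0.36 log units; beyond the scatter), toward less compound tolerated. The amide side also moves the read-out, since 4-fluorophenyl in place of 4-fluorobenzyl on an amide-type nitrogen gives an at least 2.7-fold lower number from compound 1 to compound 3 (0.44 log units; beyond the scatter). The value of compound 1 is a limit of the assay and not a number: the limit of > 100000 nM in this assay, at which 1 of the 3 values shown sits.

As far as these compounds go, whether the lower number is particular to 3-fluorophenyl stays open, as a single step cannot separate it from what a plain phenyl, or a phenyl carrying an amine or a carboxylic acid, would give on the aromatic nitrogen. Also open, from the compounds shown here alone, are a longer chain on the amide-type nitrogen and whether the amide change gives a similar step alongside 1,3-thiazol-2-yl.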